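Swapping Thiophene for Pyridine on the Oxadiazole Cap

The compounds below may be only part of what the source reports. "The series", "measured", "known", "first", "only" and "open" are said of these compounds alone.

Compound 1 `O=C(CCCCCCc1nc(-c2ccc(F)cc2)no1)NO`: 8760 nM
Compound 2 `O=C(CCCCCCc1nc(-c2cccs2)no1)NO`: 1920 nM

Going by the values given here, in an assay on isolated protein for inhibition of histone deacetylase 8 (Homo sapiens), read by fluorescence, with a stated time of 10 min (a lower number here means a stronger inhibitor, a higher number a weaker inhibitor), compound 2 holds the lowest number of the two measured, and the only step so far, a 4.6-fold lower number from compound 1 to compound 2 (0.66 log units; beyond the scatter), shows that exchanging the aryl group on the shared core changes the number noticeably. Compound 3 `O=C(CCCCCCc1nc(-c2cccnc2)no1)NO` carries the change (pyridin-3-yl in place of thiophen-2-yl on an aromatic carbon). Among the compounds with values here, that earlier aryl swap is the sole guide, and it ran from a six-membered ring to a five-membered one; compound 3 returns to a six-membered ring, so a move back toward the higher number is expected, though without a direct precedent for pyridine. The estimate for compound 3 is 4000 nM, spanning 1500 nM to 12000 nM, a step of a 2.1-fold higher number from compound 2 to compound 3 (0.32 log units; beyond the scatter).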

Compound 3, half-maximal inhibitory concentration: 1830 nM
The estimate for compound 3 lay 2.2-fold (0.34 log units) above the measured number; the measured number falls inside the stated range.
By their numbers in this assay, from the lowest: compounds 3 and 2 (each within the scatter of the next); then compound 1.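

In this assay, a five-membered ring at this position gives way to a six-membered one with a 1.0-fold lower number from compound 2 to compound 3 (0.02 log units; within the scatter), so ring size alone does not set the number among these compounds. The other step, a 4.8-fold lower number from compound 1 to compound 3 (0.68 log units; beyond the scatter), shows that two six-membered rings at this same position can still differ clearly. No measurement at hand explains this difference. Going by these compounds, whether a plain phenyl or a pyridin-4-yl group would sit closer to compound 1 or to compound 3 remains open, as does the effect of a longer chain.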